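A Biaryl Sulfonamide Series and One Untested Analogue

A few compounds are considered here, and "the series" means these few. Any claim that something is new, unique, unknown or untested is made for them only; others in the source may bear on it.

Compound 1 `COc1ccccc1-c1cccc(S(=O)(=O)N2CCC(N3CCC(C)CC3)CC2)c1` gives the lowest number of the three measured compounds in a functional assay on DLD-1 cells (Homo sapiens) for antiproliferative activity, read by CellTiter-Glo, with a stated time of 72 h (on this read-out higher numbers stand for weaker inhibition and lower numbers for stronger inhibition), at 21 nM. In this assay compound 3 `CC1CCN(C2CCN(S(=O)(=O)c3ccc(F)cc3F)CC2)CC1` gives 102 nM, and compound 2 `COc1ccc(S(=O)(=O)N2CCC(N3CCC(C)CC3)CC2)cc1OC` gives 138 nM; both of these gaps to compound 1 lie beyond the usual scatter. Compound 4 `Cc1ccc(-c2cccc(S(=O)(=O)N3CCC(N4CCC(C)CC4)CC3)c2)cc1` has not yet been measured in this assay. It differs from compound 1 in one place: 4-methylphenyl in place of 2-methoxyphenyl on an aromatic carbon. Going by the values given here, no measured pair shows a change of this kind, so the size of the step rests on compound 1 alone. The step of a 1.9-fold higher number from compound 1 to compound 4 (0.28 log units; within the scatter) is expected to be small, toward a higher number, and within the scatter. The estimate for compound 4 in this assay is 40 nM, with a range from 12 nM to 130 nM.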

Compound 4, half-maximal inhibitory concentration: 11 nM
Beside the measured number, compound 4's estimate is 3.6-fold (0.56 log units) above it, outside the stated range (below it).
By their numbers in this assay, from the lowest: compounds 4 and 1 (each within the scatter of the next); then compounds 3 and 2 (each within the scatter of the next).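

In this assay, the step of a 1.9-fold lower number from compound 1 to compound 4 (0.28 log units; within the scatter) shows that this aromatic carbon accepts 4-methylphenyl as well as 2-methoxyphenyl, so the hydrogen-bond acceptor of the leaving group is not needed to hold a number of this size. Exchanging the group and moving its substituent together leaves the value within the scatter, and the two changes cannot be told apart here. No evidence at hand accounts for this result. The compounds shown leave open how a pyridine ring, or a phenyl ring carrying a carboxylic acid or an amine, would fare at this carbon.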